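Swapping 3-chloropropyl for 4-methylphenyl on a sulfonyl sulfur

The source may report more compounds than this note shows. Statements on the series, on what has been measured and on what is new or still open speak of the compounds shown alone.

- Compound 1 `CS(=O)(=O)N1CCC2(CC1)OOC1(CCCCC1)OO2` gives > 100 ug/mL (a limit)
- Compound 2 `O=S(=O)(CCCCl)N1CCC2(CC1)OOC1(CCCCC1)OO2` gives > 100 ug/mL (a limit)

In a functional assay on Huh-7 cells (Homo sapiens) for cytotoxicity, read by MTT assay, with a stated time of 72 h (on this read-out higher numbers stand for lower toxicity in this test and lower numbers for higher toxicity in this test), compound 2 gives > 100 ug/mL as a limit of the assay, not a number. Compound 1 is also known only through a limit, so compound 2 has no exact numerical place. The unmeasured compound 3 `Cc1ccc(S(=O)(=O)N2CCC3(CC2)OOC2(CCCCC2)OO3)cc1` keeps the shared core but carries 4-methylphenyl in place of 3-chloropropyl on a sulfonyl sulfur and has yet to be tested. For the measured compounds named here, the only measured step, a step that the two limits leave unreadable from compound 1 to compound 2, bears on this change, yet its size cannot be read. Both measured compounds sit at the same limit, as the limit of > 100 ug/mL in this assay, at which 2 of the 2 values shown sit, shows. Neither carries 4-methylphenyl, so the data offer only weak guidance on this new group. They support no shift beyond the scatter and no direction. The step of a number no higher from compound 2 to compound 3 (the limit leaves the size open) is therefore expected to stay within the usual scatter. Compound 3 is estimated at 100 ug/mL with an expected range from 45 ug/mL to 200 ug/mL in this assay. Compound 3 is also expected to possibly give only a limit of the assay.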

Compound 3, half-maximal cytotoxic concentration: > 100 ug/mL
Compound 3 gave a limit, no number; the forecaster's own chance of this, stated with the estimate: 65%; the middle value sits exactly at the limit.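

No step can be read in this assay among compound 1, compound 2 and compound 3, because each gives only a limit of the assay, not a number: the limit of > 100 ug/mL in this assay, at which 3 of the 3 values shown sit.

The compounds shown leave open how far each lies from that limit, and whether methyl, 3-chloropropyl or 4-methylphenyl on the sulfonyl sulfur makes any difference in this assay.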